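The source may hold more compounds than are shown below. What is called first, only, known or untested is meant among the compounds shown, and "the series" means these compounds.

Working notes on the series. Compound 1 `CC(=O)Nc1cccc2c(-c3cccc(NC(=O)c4ccc5c(c4)OCCO5)c3)ccnc12` and compound 2 `CC(=O)Nc1cccc2c(-c3cc(NC(=O)c4ccc(Cl)c(C(F)(F)F)c4)ccc3C)ccnc12` share the same core and differ at two places: the aryl group on the amide carbonyl and the ring that carries the amide. In a functional assay on A375P cells (Homo sapiens) for antiproliferative activity, read by MTT assay, with a stated time of 48 h (a higher number here means a weaker inhibitor, a lower number a stronger inhibitor), compound 1 gives 570 nM, while compound 2 gives 12200 nM. Among the measured compounds shown here, compound 2 therefore stands at the highest of the two numbers so far; the gap to compound 1 lies beyond the scatter. For the measured compounds named here, no single-change step between measured compounds is available.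

Compound 3 `CC(=O)Nc1cccc2c(-c3cc(NC(=O)c4ccc5c(c4)OCCO5)ccc3C)ccnc12` is reached from compound 2 by 2,3-dihydro-1,4-benzodioxin-6-yl in place of 4-chloro-3-(trifluoromethyl)phenyl on a carbonyl carbon. Compound 3 carries the same amide aryl group as compound 1, with the value 570 nM of compound 1 in mind, but keeps the ring of compound 2. Compound 3 is expected to move toward a lower number, with a step of a 4.1-fold lower number from compound 2 to compound 3 (0.61 log units; beyond the scatter) that is estimated to lie beyond the scatter. Compound 3 is estimated at 3000 nM, within a range from 700 nM to 13000 nM.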

Compound 3, half-maximal inhibitory concentration: 250 nM
The estimate for compound 3 lay 12-fold (1.08 log units) above the measured number; the whole stated range lies above it.
By their numbers in this assay, from the lowest: compound 3; then compound 1; then compound 2.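

In this assay, with the methyl-carrying ring held fixed, 2,3-dihydro-1,4-benzodioxin-6-yl in place of 4-chloro-3-(trifluoromethyl)phenyl on a carbonyl carbon gives a large step (a 49-fold lower number from compound 2 to compound 3 (1.69 log units; beyond the scatter)), which isolates the effect of the amide aryl group, something the earlier pair, differing at two places, could not do. With that aryl group held fixed, methyl in place of hydrogen on an aromatic carbon gives a modest step (a 2.3-fold lower number from compound 1 to compound 3 (0.36 log units; beyond the scatter)), so here the methyl goes with a lower number, not a higher one. Nothing available bears on the cause of either step.

Going by these compounds, whether an ethyl or a methoxy group in place of that methyl would give a similar step remains open. So does whether a plain phenyl or a 4-methoxyphenyl group on the carbonyl carbon would match 2,3-dihydro-1,4-benzodioxin-6-yl.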